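Chloro to bromo swap carried across two related cores

This account rests on a few compounds, and the source may have more. Where it says the series, first, only, none or still open, it means among the compounds named here.

Measured compounds in a functional assay on A549 cells (Homo sapiens) for inhibition, read by MTT assay, with a stated time of 48 h; a lower number here means a stronger inhibitor, a higher number a weaker inhibitor:
compound 1 `Cn1c(=O)[nH]c2nc(SCC(=O)c3ccc(Cl)cc3)[nH]c2c1=O` gives 8100 nM
compound 2 `Cn1c(=O)[nH]c2nc(SCC(=O)c3ccc(Br)cc3)[nH]c2c1=O` gives 11900 nM
compound 3 `Cn1c(=O)c2[nH]c(SC/C(=N/O)c3ccc(Cl)cc3)nc2n(C)c1=O` gives 1500 nM

Compound 1 and compound 2 share one core and differ only in the change (bromo in place of chloro on an aromatic carbon); in this assay this gave a 1.5-fold higher number from compound 1 to compound 2 (0.17 log units; within the scatter). Compound 3 sits on a second core; the difference between the two cores is not broken down here. Compound 3 stands lowest of the three numbers, with compound 1 nearest and compound 2 furthest, both gaps beyond the scatter.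

Compound 4 `Cn1c(=O)c2[nH]c(SC/C(=N/O)c3ccc(Br)cc3)nc2n(C)c1=O` is not yet measured. It differs from compound 3 by bromo in place of chloro on an aromatic carbon, the same change as from compound 1 to compound 2, at the same place: on an aromatic carbon of a six-membered aromatic ring of carbon only, para to a large group.

Within the data shown here, only the one earlier instance is available, so the expectation rests on it. From compound 3 to compound 4 a step of about a 1.4-fold higher number from compound 3 to compound 4 (0.15 log units; within the scatter) is expected in this assay, beside the earlier step, because the earlier instance gave a 1.5-fold higher number from compound 1 to compound 2 (0.17 log units; within the scatter). Compound 4 is thus estimated at 2100 nM, with a range from 1100 nM to 4200 nM.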

Compound 4, half-maximal inhibitory concentration: 1800 nM
Compound 4: the middle estimate sits 1.2-fold (0.07 log units) above what was measured; the measured number falls inside the stated range.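

In this assay, bromo in place of chloro on the second core gives a 1.2-fold higher number from compound 3 to compound 4 (0.08 log units; within the scatter), a step as small as the one seen on the first core. Set side by side, the two steps do not differ: the same change on two cores in this assay, a 1.5-fold higher number (0.17 log units; within the scatter) from compound 1 to compound 2 and a 1.2-fold higher number (0.08 log units; within the scatter) from compound 3 to compound 4, 1.2-fold (0.09 log units) apart, within the scatter of two such steps

Among these compounds, the 4-chlorophenyl to 4-bromophenyl swap therefore carries across these two cores with no readable effect on the number, but this rests on only two pairs, and with both steps inside the scatter, it gives no direction for the change and says nothing about other cores or other assays.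

Every compound shown has chloro or bromo at this place on the ring, so the outcome with fluoro, methoxy, a nitrile, an amine or a carboxylic acid there remains open. The carbonyl of compound 1 and the hydroxyimino group of compound 3 stand on different cores, which leaves the share of that side chain and the share of the core in their values unseparated.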